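A propyl-to-hydrogen change on the anilino ring

A few compounds are considered here, and "the series" means these few. Any claim that something is new, unique, unknown or untested is made for them only; others in the source may bear on it.

Of the compounds shown here, three have been measured: compound 1 `COc1ccc(Nc2ccc3c(c2)C(=O)N(C2CCC(=O)NC2=O)C3=O)cc1`, compound 2 `COc1ccc(Nc2cccc3c2C(=O)N(C2CCC(=O)NC2=O)C3=O)cc1` and compound 3 `CCCc1ccc(Nc2cccc3c2C(=O)N(C2CCC(=O)NC2=O)C3=O)cc1`. In an assay on FRT-Jurkat cells for inhibition of nuclear factor NF-kappa-B complex (Homo sapiens), read by flow cytometry, with a stated time of 24 h, tested at 10 uM (a lower number here means less inhibition, a higher number more inhibition at the concentration tested (going by the name of the read-out)), compound 1 gives 29%, compound 2 gives 13% and compound 3 gives 23%. Compound 3 thus sits between the other two numbers, but both gaps fall within the scatter, so the three compounds cannot be separated from one another on these data.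

Compound 4 `O=C1CCC(N2C(=O)c3cccc(Nc4ccccc4)c3C2=O)C(=O)N1` is the next compound for this assay. It differs from compound 3 by hydrogen in place of propyl on an aromatic carbon. Within the data shown here, only one measured step speaks to this position: the change from methoxy to propyl gave a number 10 percentage points higher from compound 2 to compound 3 (within the scatter), a move that stays within the scatter. Compound 1 and compound 2 differ elsewhere and do not inform this step. Among the measured compounds shown here, since the one change at this carbon produced no clear shift, the removal of the propyl group is expected to leave the number near that of compound 3, and the step of a number 5 percentage points lower from compound 3 to compound 4 (within the scatter) is estimated to stay within the scatter. Compound 4 is therefore expected to give about 18%, within a range of 5% to 32%.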

Compound 4, a percentage reported as inhibition, at one concentration (the size of the read-out at that concentration, not a potency): 4%
Estimate against measurement, compound 4: 14 percentage points above; measured number below the stated range.
By their numbers in this assay, from the lowest: compounds 4, 2, 3 and 1 (each within the scatter of the next, the first and the last beyond it).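

In this assay the aromatic carbon para to a large group now gives its first step beyond the scatter: the change from 4-propylphenyl to phenyl yields a number 19 percentage points lower from compound 3 to compound 4 (beyond the scatter) and thus separates this pair, which the earlier change at this carbon, a number 10 percentage points higher from compound 2 to compound 3 (within the scatter), had not done for its own pair. Hydrogen in place of methoxy at the same carbon gives a number 9 percentage points lower from compound 2 to compound 4 (within the scatter), so the compound with the methoxy group cannot be told apart from either the compound with hydrogen or the compound with propyl, and only the propyl and hydrogen ends of this short series stand clearly apart. Nothing measured for these compounds offers a reason for the step from propyl to hydrogen.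

The compounds shown leave open whether a shorter chain such as ethyl or a longer chain such as butyl at this carbon would fall with propyl or with hydrogen, and what an amine or a carboxylic acid there would give. Going by these compounds, whether hydrogen in place of methoxy behaves the same way on the core of compound 1 also remains open.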